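A few compounds are considered here, and "the series" means these few. Any claim that something is new, unique, unknown or untested is made for them only; others in the source may bear on it.

Measured in a functional assay on T47D cells (Homo sapiens) for cytotoxicity, read by CCK-8 assay; on this read-out lower numbers stand for stronger inhibition and higher numbers for weaker inhibition:
compound 1 `Oc1cccc(-c2cc(-c3ccccn3)cc(-c3ccccc3O)n2)c1` gives 2560 nM
compound 2 `Oc1ccc(-c2cc(-c3ccccn3)cc(-c3ccccc3O)n2)cc1` gives > 50000 nM, which is a limit of the assay and not a number
compound 3 `Oc1cccc(-c2cc(-c3cccnc3)cc(-c3cccc(O)c3)n2)c1` gives > 50000 nM, which is a limit of the assay and not a number

The change from compound 1 to compound 2 is 4-hydroxyphenyl in place of 3-hydroxyphenyl on an aromatic carbon. In this assay it produced an at least 19-fold higher number from compound 1 to compound 2 (1.29 log units; beyond the scatter), and the pair ends at the limit of > 50000 nM in this assay, at which 2 of the 3 values shown sit.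

Compound 4 `Oc1ccc(-c2cc(-c3cccnc3)cc(-c3cccc(O)c3)n2)cc1` has not yet been measured. It differs from compound 3 by 4-hydroxyphenyl in place of 3-hydroxyphenyl on an aromatic carbon, the same kind of change as in the first pair, but around a place that is meta to a 3-hydroxyphenyl group and meta to a pyridin-3-yl group rather than meta to a 2-hydroxyphenyl group and meta to a pyridin-2-yl group. The difference between the core of compound 1 and the core of compound 3 is not broken down here.

Among the measured compounds shown here, only a limit is known for compound 3, so no numerical step to compound 4 can be drawn. In this assay compound 4 is expected to sit at 60000 nM. That expectation rests on compound 3 already standing at the limit of > 50000 nM in this assay, at which 2 of the 3 values shown sit, and on the earlier change having given an at least 19-fold higher number from compound 1 to compound 2 (1.29 log units; beyond the scatter). The expected step is therefore estimated as a step that the limit leaves unreadable from compound 3 to compound 4, a compound most likely reported again as a limit.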

Compound 4, half-maximal inhibitory concentration: > 50000 nM
Compound 4 gave a limit, no number; the forecaster's own chance of this, stated with the estimate: 85%; the middle value does not contradict the limit.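

In this assay compound 4 gives > 50000 nM, a limit of the assay and not a number. Compound 3 also stands at a limit, so no step can be read between compound 3 and compound 4: the limit of > 50000 nM in this assay, at which 3 of the 4 values shown sit.

The compounds shown leave open whether 4-hydroxyphenyl in place of 3-hydroxyphenyl raises the number around the core of compound 3 as it does around the core of compound 1.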